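The source may report more compounds than this note shows. Statements on the series, on what has been measured and on what is new or still open speak of the compounds shown alone.

Working notes on the series. Compound 2 `FC(F)(F)c1ccc(CN2CCN(Cc3cc(-c4ccc(OCc5ccc(Cl)cc5)cc4)on3)CC2)cc1` gives 4000 nM in a functional assay on Huh-7 cells (Homo sapiens) for antiproliferative activity, read by sulforhodamine B assay, with a stated time of 72 h (on this read-out higher numbers stand for weaker inhibition and lower numbers for stronger inhibition), the highest number among the three measured compounds; the nearest is compound 3 `Fc1cccc(COc2ccc(-c3cc(CN4CCN(Cc5ccc(C(F)(F)F)cc5)CC4)no3)cc2)c1`, which gives 1300 nM, and the furthest is compound 1 `FC(F)(F)c1ccc(CN2CCN(Cc3cc(-c4ccc(OCc5ccccc5Cl)cc4)on3)CC2)cc1`, which gives 1000 nM. Compound 4 `COc1cccc(COc2ccc(-c3cc(CN4CCN(Cc5ccc(C(F)(F)F)cc5)CC4)no3)cc2)c1` has not yet been measured. It differs from compound 2 in one place: 3-methoxyphenyl in place of 4-chlorophenyl on a saturated chain carbon bound to an oxygen on an aromatic ring.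

Going by the values given here, two measured steps bear on this change, both at the same place. The step of a 3.1-fold lower number from compound 2 to compound 3 (0.49 log units; beyond the scatter) shows that exchanging the 4-chlorophenyl for a halogenated phenyl with its substituent elsewhere on the ring lowers the number clearly. The step of a 1.3-fold higher number from compound 1 to compound 3 (0.11 log units; within the scatter) shows that 2-chlorophenyl and 3-fluorophenyl give numbers that cannot be told apart. Among the compounds with values here, no measured pair compares a methoxy with a halogen at this place, so the weight of the oxygen-bearing group itself is unknown. Given that compound 2 sits alone at the high end, a modest lowering is expected, in the direction seen from compound 2 to compound 3, and a step of about a 2.5-fold lower number from compound 2 to compound 4 (0.40 log units; beyond the scatter) is estimated. Compound 4 is therefore expected to give about 1600 nM in this assay, with a range of 600 nM to 5000 nM.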

Compound 4, half-maximal inhibitory concentration: 800 nM
Compound 4: middle estimate off by 2.0-fold (0.30 log units), on the high side; measured number inside the range.
By their numbers in this assay, from the lowest: compounds 4, 1 and 3 (each within the scatter of the next); then compound 2.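

The methoxy result shows that a substituent other than a halogen can stand at this place without the number rising in this assay, and a 5.0-fold lower number from compound 2 to compound 4 (0.70 log units; beyond the scatter) leaves compound 2 alone at the high end among four aryl groups. With a 1.6-fold lower number from compound 3 to compound 4 (0.21 log units; within the scatter) and a 1.3-fold lower number from compound 1 to compound 4 (0.10 log units; within the scatter), the 3-methoxyphenyl cannot be told apart from the 3-fluorophenyl or the 2-chlorophenyl, so these three groups now form a single cluster despite their different substituents. Going by these compounds alone, the 4-chlorophenyl is the only group here that stands apart from that cluster, and no measurement on hand explains this.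

The compounds shown cannot separate the identity of the substituent from where it sits on the phenyl, as compound 2 is the only one carrying the 4-chlorophenyl and no other group is compared with it at matching ring placement. From the compounds shown here alone, it also remains open how this place would respond to a phenyl with no substituent, or to a phenyl carrying an amine or a carboxylic acid in place of the methoxy.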